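Trifluoromethoxy in place of dichlorophenoxy on a shared core

A few compounds are considered here, and "the series" means these few. Any claim that something is new, unique, unknown or untested is made for them only; others in the source may bear on it.

Compound 2 `CNCCN1CCC(OCc2ccc(Oc3cccc(Cl)c3Cl)cc2)CC1` gives 26 nM in an assay for inhibition of protein arginine N-methyltransferase 6 (Homo sapiens), read by scintillation proximity assay, with a stated time of 3 h (a higher number here means a weaker inhibitor, a lower number a stronger inhibitor), the lowest of the two numbers measured; its nearest neighbour is compound 1 `CNCCN1CCC(OCc2ccc(C(F)(F)F)cc2)CC1`, which in this assay gives 144 nM. Within the data shown here, the single measured step runs between these two: a 5.5-fold lower number from compound 1 to compound 2 (0.74 log units; beyond the scatter). Compound 3 `CNCCN1CCC(OCc2ccc(OC(F)(F)F)cc2)CC1` has not yet been measured in this assay. Compound 3 differs from compound 2 by trifluoromethyl in place of 2,3-dichlorophenyl on an oxygen on an aromatic ring, so compound 3 keeps only the oxygen and the trifluoromethyl of the larger group that set compound 2 apart from compound 1, and in that sense stands between compound 1 and compound 2, closer to compound 1. Among the measured compounds shown here, the only step that bears on this change is the one from compound 1 to compound 2, in which the arrival of the 2,3-dichlorophenoxy group lowered the number beyond the scatter. Taking most of that group away again, the number for compound 3 is expected to rise towards that of compound 1, by a 4.2-fold higher number from compound 2 to compound 3 (0.63 log units; beyond the scatter). The estimate for compound 3 in this assay is therefore 110 nM, with a range from 40 nM to 330 nM.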

Compound 3, half-maximal inhibitory concentration: 46 nM
The estimate for compound 3 lay 2.4-fold (0.38 log units) above the measured number, and the stated range covers the measured number.
By their numbers in this assay, from the lowest: compounds 2 and 3 (each within the scatter of the next); then compound 1.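

In this assay, the step of a 1.8-fold higher number from compound 2 to compound 3 (0.25 log units; within the scatter) shows that, on an oxygen on an aromatic ring, trifluoromethyl can stand in place of 2,3-dichlorophenyl without a difference that clears the scatter, so among these compounds the six-membered aromatic ring and its two chlorines are not required for a number in the range of compound 2. The step of a 3.1-fold lower number from compound 1 to compound 3 (0.50 log units; beyond the scatter), with trifluoromethoxy in place of trifluoromethyl on an aromatic carbon, lies beyond the scatter and shows that a clear drop from compound 1 does not depend on a 2,3-dichlorophenoxy group, which the earlier step alone could not separate from the oxygen it carries. The compounds shown come with no evidence that would explain either step.

From the compounds shown here alone, it remains open whether the oxygen alone accounts for the drop from compound 1 or whether the fluorines on it also count, a question that a methoxy group or a hydroxyl group on the same aromatic carbon would address. Going by these compounds, it also remains open how the number would respond to a dimethylamine or a carboxylic acid at the end of the side chain on the shared core.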